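Methyl to Propyl on an Inactive Shared Core

The source may hold more compounds than are shown below. What is called first, only, known or untested is meant among the compounds shown, and "the series" means these compounds.

Measured so far:
Compound 1, `Cc1ccc(C(=O)CSc2nnc(C)n2N2C(=O)c3ccccc3C2=O)cc1` — in a functional assay on A549 cells (Homo sapiens) for cytotoxicity, read by MTT assay, with a stated time of 48 h (on this read-out lower numbers stand for stronger inhibition and higher numbers for weaker inhibition), compound 1 gives > 200000 nM, a limit of the assay.
Compound 2, `CSc1nnc(C)n1N1C(=O)c2ccccc2C1=O` — in this assay compound 2 gives > 200000 nM, also a limit of the assay.

Compound 2 therefore stands at the limit of the assay and nowhere else on the numbers shown; the limit of > 200000 nM in this assay, at which 2 of the 2 values shown sit, describes the ceiling at which both shown values sit. Among the measured compounds shown here, the only measured step, a step that the two limits leave unreadable from compound 1 to compound 2, is unreadable because both ends are limits, so it tells nothing about the size of any change on this shared core.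

Compound 3, `CCCc1nnc(SC)n1N1C(=O)c2ccccc2C1=O`, differs from compound 2 by ethyl in place of hydrogen on a saturated chain carbon bound to an aromatic carbon. No measured step bears on this change: the one step shown is unreadable, and nothing else is known. With both shown values at the same limit, the expectation for this assay is that the propyl compound again reports only a limit, with no step beyond the scatter readable.

Compound 3 is therefore estimated at 200000 nM, with a range from 60000 nM to 600000 nM. The step from compound 2 to compound 3 is expected to be a number no higher from compound 2 to compound 3 (the limit leaves the size open).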

Compound 3, half-maximal inhibitory concentration: > 200000 nM
Compound 3 gave a limit, no number; the forecaster's own chance of this, stated with the estimate: 80%; the middle value sits exactly at the limit.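

Compound 3, like compound 2, reports only a limit in this assay, so no step can be read from one to the other. All the compounds now sit at one ceiling: the limit of > 200000 nM in this assay, at which 3 of the 3 values shown sit. The compounds shown leave open whether any change on this shared core would give a measurable value in this assay.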